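Shifting One Methyl Group Around a Phenyl Ring

The compounds below may be only part of what the source reports. "The series", "measured", "known", "first", "only" and "open" are said of these compounds alone.

Compound 1 `Cc1ccccc1C1CC(c2ccc(OCc3ccccc3)cc2)=NN1c1ccc(S(N)(=O)=O)cc1`: 100000 nM
Compound 2 `Cc1ccc(C2CC(c3ccc(Oc4ccccc4)cc3)=NN2c2ccc(S(N)(=O)=O)cc2)cc1`: 86000 nM

Both numbers come from an ADME assay on Vero 76 cells (Chlorocebus sabaeus) for cytotoxicity, read by MTT assay, with a stated time of 96 h; on this read-out higher numbers stand for lower toxicity in this test and lower numbers for higher toxicity in this test. Compound 2 (86000 nM) stands within the usual scatter of compound 1 (100000 nM), so these two values cannot be told apart.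

Compound 3 `Cc1ccccc1C1CC(c2ccc(Oc3ccccc3)cc2)=NN1c1ccc(S(N)(=O)=O)cc1` differs from compound 2 in one place: it has 2-methylphenyl in place of 4-methylphenyl on a saturated ring carbon. Among the measured compounds shown here, no measured pair shows this swap alone. However, compound 1 also carries 2-methylphenyl and gives (100000 nM), although it differs from compound 3 elsewhere as well. No shift beyond the scatter is therefore expected in this assay, and the estimated step is (a 1.0-fold higher number from compound 2 to compound 3 (0.02 log units; within the scatter)). Compound 3 is expected at (90000 nM), with an estimated range from (45000 nM) to (120000 nM).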

Compound 3, half-maximal cytotoxic concentration: 90000 nM
Compound 3: middle estimate and measured number agree at the digits printed; low and high end bracket the measured number.
By their numbers in this assay, from the lowest: compounds 2, 3 and 1 (each within the scatter of the next).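

Moving the methyl group, with 2-methylphenyl in place of 4-methylphenyl on a saturated ring carbon, gives a clean comparison in this assay (a 1.0-fold higher number from compound 2 to compound 3 (0.02 log units; within the scatter)), and compound 2 and compound 3 cannot be told apart. Compound 3 also forms a single-change pair with compound 1, with phenyl in place of benzyl on an oxygen on an aromatic ring (a 1.1-fold lower number from compound 1 to compound 3 (0.05 log units; within the scatter)), so this second change cannot be told from the scatter either. Nothing measured here offers an explanation for these two results.

The compounds shown carry only a methyl group on this phenyl ring, so 3-methylphenyl remains open. So do an amine, a carboxylic acid or a longer chain such as ethyl in that place, any of which could give a different reading.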